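Chloro for Methyl on the Anilide Ring of Compound 3

This account rests on a few compounds, and the source may have more. Where it says the series, first, only, none or still open, it means among the compounds named here.

Three analogues sharing one core have been run in a functional assay on UO-31 cells (Homo sapiens) for inhibition, read by sulforhodamine B assay, tested at 10 uM; on this read-out higher numbers stand for more inhibition at the one concentration tested (going by the name of the read-out) and lower numbers for less inhibition. Compound 1 `COc1cc2oc(-c3cccc(NC(=O)c4ccc(C)cc4)c3)cc(=O)c2c(OC)c1OC` is reported in this assay only as "active" (no number reported), without a single number. Compound 2 `COc1cc2oc(-c3cccc(NC(=O)c4ccc(Cl)cc4)c3)cc(=O)c2c(OC)c1OC` gives 51.1% in this assay, and compound 3 `COc1cc2oc(-c3cccc(C(=O)Nc4ccc(C)cc4)c3)cc(=O)c2c(OC)c1OC` gives 55.7%. The step of a number 4.6 percentage points higher from compound 2 to compound 3 (within the scatter) is within the scatter, so compound 2 and compound 3 stand together, with compound 1 offering no number to place beside them.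

Compound 4 `COc1cc2oc(-c3cccc(C(=O)Nc4ccc(Cl)cc4)c3)cc(=O)c2c(OC)c1OC` differs from compound 3 by chloro in place of methyl on an aromatic carbon. Within the data shown here, no measured step isolates this exchange: the one step on record also turns the amide around, and the pair of compound 1 and compound 2, which carries the same methyl-to-chloro exchange on the other amide arrangement, lacks a number for compound 1. Among the measured compounds shown here, the only step that bears on it, from compound 2 to compound 3, was within the scatter, and the exchange itself is of a single atom. Compound 4 is therefore expected to show in this assay a step of a number 0.7 percentage points lower from compound 3 to compound 4 (within the scatter), which is no change beyond the scatter. The estimate for compound 4 in this assay is 55%, with a range from 40% to 70%.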

Compound 4, a percentage reported as inhibition, at one concentration (the size of the read-out at that concentration, not a potency): 61.4%
Beside the measured number, compound 4's estimate is 6.4 percentage points below it; measured number inside the range.
By their numbers in this assay, from the lowest: compounds 2, 3 and 4 (each within the scatter of the next, the first and the last beyond it).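

Taken alone in this assay, the exchange of methyl for chloro on the aromatic carbon para to a large group gives a number 5.7 percentage points higher from compound 3 to compound 4 (within the scatter) on this amide arrangement, so the 4-methylphenyl and 4-chlorophenyl versions of the carbamoyl group stand together at this single concentration. Turning the amide around while keeping the 4-chlorophenyl group, a comparison the earlier numbers did not allow, gives a number 10.3 percentage points higher from compound 2 to compound 4 (beyond the scatter) and is the only step among the compounds shown to pass the scatter, though only modestly. Nothing measured on these compounds accounts for either step.

The compounds shown leave open whether turning the amide around matters equally with methyl on the outer ring, since compound 1 has no single number to set against compound 3, and whether chloro and methyl would still stand together with compound 1 as the reference. They also leave open how the read-out would respond to an amine, a carboxylic acid or a longer chain at this same position on the outer ring, where only methyl and chloro are shown here.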